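Bromo for Chloro on a Shared Core in K562 Cells

The compounds below may be only part of what the source reports. "The series", "measured", "known", "first", "only" and "open" are said of these compounds alone.

The three measured compounds, all tested in a functional assay on K562 cells (Homo sapiens) for inhibition, read by sulforhodamine B assay, with a stated time of 48 h (a higher number here means a weaker inhibitor of growth, a lower number a stronger inhibitor of growth), are:

Compound 1, `CC(C)(C)NCc1c(C(=O)O)nn(-c2ccccc2)c1-c1ccc(Cl)cc1`, with 364000 nM.
Compound 2, `CC(C)(C)NCc1c(C(=O)O)nn(-c2ccccc2)c1-c1ccc(Br)cc1`, with > 585000 nM, which is a limit of the assay and not a number.
Compound 3, `CC(C)(C)NCc1c(C(=O)O)nn(-c2ccc(Cl)cc2)c1-c1ccc(Cl)cc1`, with 290000 nM.

Compound 3 differs from compound 1 in one place: chloro in place of hydrogen on an aromatic carbon. In this assay this gives a 1.3-fold lower number from compound 1 to compound 3 (0.10 log units; within the scatter), so the two values cannot be told apart.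

Compound 2 differs from compound 1 by bromo in place of chloro on an aromatic carbon. The step is an at least 1.6-fold higher number from compound 1 to compound 2 (0.20 log units; that floor lies within the scatter), and its size is known only as a floor because compound 2 sits at the limit of > 585000 nM in this assay, at which 1 of the 3 values shown sits.

The unmeasured compound 4 is `CC(C)(C)NCc1c(C(=O)O)nn(-c2ccc(Cl)cc2)c1-c1ccc(Br)cc1`. It differs from compound 3 by bromo in place of chloro on an aromatic carbon, the same change that separates compound 1 and compound 2, made on the core of compound 3 rather than the core of compound 1. The place of the change reads the same in both cases.

The expectation for compound 4 rests on compound 3 and its value 290000 nM together with the step from compound 1 to compound 2, an at least 1.6-fold higher number from compound 1 to compound 2 (0.20 log units; that floor lies within the scatter). Compound 4 is therefore expected to give 480000 nM in this assay, with a plausible span from 250000 nM to 900000 nM. The expected step from compound 3 to compound 4 is a 1.7-fold higher number from compound 3 to compound 4 (0.22 log units; within the scatter). There is a fair chance that compound 4, like compound 2, is reported only as a limit.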

Compound 4, concentration for 50% growth inhibition: 297000 nM
Estimate against measurement, compound 4: 1.6-fold (0.21 log units) above, and the stated range covers the measured number.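

On the core of compound 3, bromo in place of chloro, the change from 4-chlorophenyl to 4-bromophenyl, gives a 1.0-fold higher number from compound 3 to compound 4 (0.01 log units; within the scatter) in this assay, and set beside the step on the core of compound 1, this shows neither that the change carries over with the same size nor that it does not: the same change on two cores in this assay, an at least 1.6-fold higher number (0.20 log units; that floor lies within the scatter) from compound 1 to compound 2 and a 1.0-fold higher number (0.01 log units; within the scatter) from compound 3 to compound 4; the limit leaves it open whether they differ. The step for chloro in place of hydrogen, now also seen on a second core as an at least 1.9-fold lower number from compound 2 to compound 4 (0.29 log units; that floor lies within the scatter), stands in the same open position beside its earlier counterpart: the same change on two cores in this assay, a 1.3-fold lower number (0.10 log units; within the scatter) from compound 1 to compound 3 and an at least 1.9-fold lower number (0.29 log units; that floor lies within the scatter) from compound 2 to compound 4; the limit leaves it open whether they differ. Compound 2 is reported as > 585000 nM, which is a limit and not a number, and neither comparison settles how far either change carries from one core to the other.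

The compounds shown leave open whether the exchange of bromo for chloro would read the same with a fluoro group or a methyl group at that place, or with an ester or an amide in place of the carboxylic acid. They also leave open what would happen with a smaller amine in place of the tert-butylamine, since all four compounds carry that same group.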